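Varying the ring-nitrogen aryl group in an osteosarcoma cell assay

The source may report more compounds than this note shows. Statements on the series, on what has been measured and on what is new or still open speak of the compounds shown alone.

Measured compounds:
- compound 1, `CCN(CC)c1ccc(N2C(=O)CSC2c2cccc(C(=O)NCCCCc3ccccc3)c2)cc1`: > 1000 nM
- compound 2, `O=C(NCCCCc1ccccc1)c1cccc(C2SCC(=O)N2c2nccs2)c1`: > 1000 nM
- compound 3, `COc1c(F)cccc1N1C(=O)CSC1c1cccc(C(=O)NCCCCc2ccccc2)c1`: 26.2 nM

Three compounds sharing one core differ only in the group on the amide-type nitrogen of the five-membered ring. In a functional assay on HOS-TE85 cells (Homo sapiens) for inhibition, read by CCK-8 assay, with a stated time of 72 h (a lower number here means a stronger inhibitor, a higher number a weaker inhibitor), compound 1 reaches only the limit > 1000 nM, which is a bound of the assay and not a number. Compound 2 likewise stops at the limit > 1000 nM. Among the compounds with values here, compound 3, with a 3-fluoro-2-methoxyphenyl on that nitrogen, gives 26.2 nM, the only real number among the three, so it stands as the sole compound with a measured potency here (the limit of > 1000 nM in this assay, at which 2 of the 3 values shown sit).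

The steps to compound 3 are large: an at least 38-fold lower number from compound 1 to compound 3 (1.58 log units; beyond the scatter) and an at least 38-fold lower number from compound 2 to compound 3 (1.58 log units; beyond the scatter). The step that the two limits leave unreadable from compound 1 to compound 2 cannot be read because both ends are limits.

Compound 4, `O=C(NCCCCc1ccccc1)c1cccc(C2SCC(=O)N2c2ccccc2F)c1`, alters compound 3 in this way: 2-fluorophenyl in place of 3-fluoro-2-methoxyphenyl on an amide-type nitrogen in a ring. Within the data shown here, no measured step changes this aryl group while keeping its aromatic carbon ring, so the measured steps only show that the nitrogen substituent can move potency strongly. A modest loss is therefore expected, a 3.4-fold higher number from compound 3 to compound 4 (0.54 log units; beyond the scatter), with wide uncertainty. Compound 4 is estimated at 90 nM, within 20 nM to 600 nM in this assay.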

Compound 4, half-maximal inhibitory concentration: 34.1 nM
For compound 4 the middle estimate is 2.6-fold (0.42 log units) above the measured one; the range from low to high includes it.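

In this assay, the exchange of 3-fluoro-2-methoxyphenyl for 2-fluorophenyl on the amide-type nitrogen gives a 1.3-fold higher number from compound 3 to compound 4 (0.11 log units; within the scatter), so the two groups cannot be told apart here, and the methoxy group of compound 3 is not required for a measured potency in this pair. The second measured compound also shows that the low value is not confined to a single group on this nitrogen, with an at least 29-fold lower number from compound 2 to compound 4 (1.46 log units; beyond the scatter) and an at least 29-fold lower number from compound 1 to compound 4 (1.46 log units; beyond the scatter), although compound 1 goes against any reading that a six-membered aromatic ring of carbon alone is enough. Compound 1 and compound 2 each stand at a limit and not at a number, so both of these large steps are bounds: the limit of > 1000 nM in this assay, at which 2 of the 4 values shown sit.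

As far as these compounds go, what an unsubstituted phenyl or a chlorophenyl would give on this nitrogen remains open, and with it whether the fluorine shared by compound 3 and compound 4 contributes at all. Also open, from the compounds shown here alone, is whether a pyridine ring, or a smaller dimethylamino group in place of the diethylamino group of compound 1, would restore a measurable value.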